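This account rests on a few compounds, and the source may have more. Where it says the series, first, only, none or still open, it means among the compounds named here.

In a functional assay on ID8 cells (Mus musculus) for antiproliferative activity (a lower number here means a stronger inhibitor, a higher number a weaker inhibitor), compound 3 (`CC(C)C[C@H](NC(=O)OC(C)(C)C)C(=O)Nc1ccc(O)c2c(=O)cc(-c3ccccc3Cl)oc12`) gives 5100 nM and compound 2 (`C[C@H](NC(=O)OC(C)(C)C)C(=O)Nc1ccc(O)c2c(=O)cc(-c3ccccc3Cl)oc12`) gives 9800 nM, two values within the scatter of each other. Compound 1 (`CSCC[C@@H](NC(=O)OC(C)(C)C)C(=O)Nc1ccc(O)c2c(=O)cc(-c3ccccc3Cl)oc12`) gives 13000 nM as a higher number than compound 3 shows, beyond the scatter.

Compared with compound 3, compound 4 (`CSCC[C@H](NC(=O)OC(C)(C)C)C(=O)Nc1ccc(O)c2c(=O)cc(-c3ccccc3Cl)oc12`) carries (methylsulfanyl)methyl in place of isopropyl on a saturated chain carbon, two bonds along the chain from an amide-type nitrogen and a carbonyl carbon. Among the measured compounds shown here, the one measured step at this place is a 1.9-fold lower number from compound 2 to compound 3 (0.28 log units; within the scatter) and it stays within the scatter, so it gives no sign of a large change. For the measured compounds named here, no measured step makes this exact exchange. Going by the values given here, compound 1, the only measured compound with a 2-(methylsulfanyl)ethyl chain, at 13000 nM tilts the expectation slightly toward a higher number.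

No step beyond the scatter is therefore expected in this assay for this change. The estimated size is a 1.5-fold higher number from compound 3 to compound 4 (0.17 log units; within the scatter) and no more than that is expected. The estimate for compound 4 is 7500 nM with an expected range from 3500 nM to 16000 nM in four of five measurements.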

Compound 4, half-maximal inhibitory concentration: 6200 nM
Estimate against measurement, compound 4: 1.2-fold (0.08 log units) above; the measured number falls inside the stated range.
By their numbers in this assay, from the lowest: compounds 3, 4, 2 and 1 (each within the scatter of the next, the first and the last beyond it).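

In this assay, the exchange of isopropyl for (methylsulfanyl)methyl at this saturated chain carbon reads as a 1.2-fold higher number from compound 3 to compound 4 (0.08 log units; within the scatter), and the exchange of hydrogen for the same group reads as a 1.6-fold lower number from compound 2 to compound 4 (0.20 log units; within the scatter), so compounds 2, 3 and 4 do not separate at this place. Among the compounds shown here, the only new step beyond the scatter, and a modest one, is a 2.1-fold lower number from compound 1 to compound 4 (0.32 log units; beyond the scatter); it can be assigned to the stereocentre at that carbon alone, on this ground: the fact that compounds 1 and 4 differ only in the configuration as drawn. The number for compound 1 therefore gives no case against the 2-(methylsulfanyl)ethyl chain itself.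

Whether inverting the stereocentre has a similar effect with the side chains of compound 2 and compound 3 remains open, with only one such pair shown. Also open, going by these compounds, is how a chain ending in an amine or a carboxylic acid would read at this place.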